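Stereochemistry Loosened in a Nitrobenzenesulfonyl Series

The source may hold more compounds than are shown below. What is called first, only, known or untested is meant among the compounds shown, and "the series" means these compounds.

Measured compounds:
- compound 1, `Cc1cn(C2CN(S(=O)(=O)c3ccccc3[N+](=O)[O-])c3ccccc3CO2)c(=O)[nH]c1=O`: 45200 nM
- compound 2, `O=[N+]([O-])c1ccc(S(=O)(=O)N2C[C@H](n3cnc4c(Cl)nc(Cl)nc43)OCc3ccccc32)cc1`: 190 nM

In a functional assay on MCF7 cells (Homo sapiens) for cytotoxicity, read by sulforhodamine B assay, with a stated time of 3 days (a higher number here means a weaker inhibitor, a lower number a stronger inhibitor), compound 1 gives 45200 nM and compound 2 gives 190 nM. Of the two numbers, compound 2 stands at the lowest; the nearest is compound 1, whose number is higher by a gap that lies well beyond the scatter. The two compounds differ in many places at once, so no single-point step between them can be read off; only the two values themselves are shown.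

The step to compound 3, `O=[N+]([O-])c1ccc(S(=O)(=O)N2CC(n3cnc4c(Cl)nc(Cl)nc43)OCc3ccccc32)cc1`, is a different kind of change: the two compounds have the same atoms and bonds; at least one stereo element is drawn with a configuration in one of them and without one in the other: 1 of 1 stereo elements differ; a stereocentre at a saturated ring carbon is drawn R in compound 2 and without a configuration in compound 3. In words, the two compounds have the same atoms and bonds, and the stereocentre at a saturated ring carbon that is drawn R in compound 2 is drawn without a configuration in compound 3. For the measured compounds named here, no step between measured compounds is available for this kind of change. If the drawn configuration of compound 2 carries the activity, a mixture is expected to give a somewhat higher number in this assay, likely within or near the scatter, and not a drop beyond it; a change in the other direction is not expected. For compound 3 the expected value in this assay is 350 nM, with a range from 150 nM to 1500 nM, which means an estimated step of a 1.8-fold higher number from compound 2 to compound 3 (0.27 log units; within the scatter).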

Compound 3, half-maximal inhibitory concentration: 355 nM
For compound 3 the middle estimate is 1.0-fold (0.01 log units) below the measured one; the measured number falls inside the stated range.
By their numbers in this assay, from the lowest: compounds 2 and 3 (each within the scatter of the next); then compound 1.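

For the compounds shown here, the step of a 1.9-fold higher number from compound 2 to compound 3 (0.27 log units; within the scatter) in this assay is the first comparison that differs in one place only, since compounds 1 and 2 differ in too many places to isolate any single change. At the stereocentre at a saturated ring carbon, removing the drawn R configuration leaves the two numbers within the scatter of each other, so this assay does not separate the defined drawing from the undefined one. The reading of this position rests on a single contrast in how the two compounds are drawn, which says nothing about the actual composition of the sample of compound 3: the fact that one of compounds 2 and 3 is drawn with a defined configuration and the other without, at the place where they differ.

The compounds shown leave open what a form drawn S would give on its own, and so whether the configuration at this carbon matters at all in this assay or the difference is simply too small to show against the scatter. They also leave open whether the value holds when an amine or a methoxy group replaces either chlorine on the shared core, a change that would test that part of the structure at the same stereocentre.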